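Benzylsulfonyl in Place of Cyanophenylsulfonyl at the Ring Nitrogen

The source may report more compounds than this note shows. Statements on the series, on what has been measured and on what is new or still open speak of the compounds shown alone.

Compound 1 `COc1ccc(-c2cc(=O)c3c(OC)cc(OC)cc3[nH]2)cc1` in a functional assay on SUP-B15 cells (Homo sapiens) for antiproliferative activity, with a stated time of 72 h (on this read-out lower numbers stand for an effect already at smaller amounts and higher numbers for an effect only at larger amounts of compound), gives only a limit, > 62000 nM.
Compound 2 `COC(=O)c1cc(=O)c2c(OC)cc(OC)cc2n1S(=O)(=O)c1ccc(C)cc1` gives 9700 nM.
Compound 3 `COc1ccc(-c2cc(=O)c3c(OC)cc(OC)cc3n2S(=O)(=O)c2ccc(C#N)cc2)cc1` gives 7900 nM.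

Compound 3 holds the lowest of the two numbers, with compound 2 within the scatter of it. Going by the values given here, the one measured step, an at least 7.8-fold lower number from compound 1 to compound 3 (0.89 log units; beyond the scatter), rests on compound 1 sitting at the limit of > 62000 nM in this assay, at which 1 of the 3 values shown sits. Compound 4 `COc1ccc(-c2cc(=O)c3c(OC)cc(OC)cc3n2S(=O)(=O)Cc2ccccc2)cc1` differs from compound 3 as follows: benzyl in place of 4-cyanophenyl on a sulfonyl sulfur. Among the compounds with values here, no measured step touches the group on the sulfonyl sulfur, so the 1>3 step does not bear on it directly; compound 2, with another sulfonyl on the same nitrogen, sits close to compound 3. Compound 4 is therefore expected to show a 1.3-fold higher number from compound 3 to compound 4 (0.10 log units; within the scatter), a step within the scatter. The estimate for compound 4 is 10000 nM, ranging from 3000 nM to 40000 nM.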

Compound 4, half-maximal effective concentration: > 34400 nM
Compound 4: a limit, no number (the forecaster's own chance of this, stated with the estimate: 15%); middle value at least 3.4-fold (0.53 log units) from the limit.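

In this assay, benzyl in place of 4-cyanophenyl on a sulfonyl sulfur gives an at least 4.3-fold higher number from compound 3 to compound 4 (0.63 log units; beyond the scatter), so a sulfonyl on the aromatic nitrogen does not by itself secure the lower number, and the group it carries counts. Compound 4 gives only a limit, so this step has a lower bound and no exact size: the limit of > 34400 nM in this assay, at which 1 of the 4 values shown sits. The step from compound 1 to compound 4 cannot be read, with a limit at both ends.

Going by these compounds, it remains open whether the nitrile or the aromatic ring bonded directly to the sulfonyl sulfur matters more. How a phenyl carrying an amine or a carboxylic acid would read there is also unknown.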